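Adding a Second Fluorine to the Carbamate Aryl Ring

The compounds below may be only part of what the source reports. "The series", "measured", "known", "first", "only" and "open" are said of these compounds alone.

Compound 3 `CC(C)=CCC1Cc2c(OC(=O)Nc3ccccc3F)cc(=O)n(CCCO)c2CC1(C)C` stands level with compound 2 `COc1cccc(NC(=O)Oc2cc(=O)n(CCCO)c3c2CC(CC=C(C)C)C(C)(C)C3)c1` in a functional assay on PANC-1 cells (Homo sapiens) for inhibition, read by MTT assay, with a stated time of 24 h, tested at 10 uM; a lower number here means less inhibition, a higher number more inhibition at the concentration tested (going by the name of the read-out): compound 3 gives 0%, and compound 2 gives 0%. Compound 1 `CC(C)=CCOc1cc(=O)n(CCCO)c2c1CC(CC=C(C)C)C(C)(C)C2`, which carries a 3-methylbut-2-en-1-yl group on the ring oxygen rather than a carbamoyl group, gives 7.5%. None of the three numbers is separated from another by more than the scatter: a number 7.5 percentage points lower from compound 1 to compound 2 (within the scatter), a number 7.5 percentage points lower from compound 1 to compound 3 (within the scatter), and no change at the digits printed from compound 2 to compound 3 (within the scatter).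

Compound 4 `CC(C)=CCC1Cc2c(OC(=O)Nc3ccc(F)c(F)c3)cc(=O)n(CCCO)c2CC1(C)C` differs from compound 3 in one place: 3,4-difluorophenyl in place of 2-fluorophenyl on an amide-type nitrogen. The measured step that bears most directly on this change is the exchange of one aryl group for another on the amide-type nitrogen, no change at the digits printed from compound 2 to compound 3 (within the scatter). The two steps that replace the whole group on the ring oxygen also stayed inside the scatter. Going by the values given here, nothing among the measured compounds indicates that exchanging one aryl ring for another on the nitrogen moves the read-out, so no step beyond the scatter is expected here; the expected change reads a number 2 percentage points higher from compound 3 to compound 4 (within the scatter). Compound 4 is therefore estimated at 2%, with a range from -8% to 12%.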

Compound 4, a percentage reported as inhibition, at one concentration (the size of the read-out at that concentration, not a potency): 0%
The estimate for compound 4 lay 2 percentage points above the measured number; the measured number falls inside the stated range.
By their numbers in this assay, from the lowest: compounds 2, 3, 4 and 1 (each within the scatter of the next).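

In this assay, 3,4-difluorophenyl on the amide-type nitrogen does not separate from either of the other two aryl groups shown there, with no change at the digits printed from compound 3 to compound 4 (within the scatter) and no change at the digits printed from compound 2 to compound 4 (within the scatter) as the steps. A second fluorine on the carbamate aryl ring thus leaves the read-out where 2-fluorophenyl and 3-methoxyphenyl had left it, so three aryl groups at this position now give the same printed number. The exchange of 3-methylbut-2-en-1-yl on the ring oxygen for (3,4-difluorophenyl)carbamoyl, with a number 7.5 percentage points lower from compound 1 to compound 4 (within the scatter) as its step, also stays inside the scatter, and no other information on these compounds bears on the result.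

With all three carbamates level at the bottom of the read-out, the compounds shown cannot rank aryl groups at this position, and they say nothing about how the series behaves at any other concentration. As far as these compounds go, whether a phenyl ring carrying an amine or a carboxylic acid, or a longer alkyl chain in place of the aryl ring on the nitrogen, would lift the number in this assay remains open.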